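Replacing fluoro with methyl on compound 3

A few compounds are considered here, and "the series" means these few. Any claim that something is new, unique, unknown or untested is made for them only; others in the source may bear on it.

Measured so far in a physicochemical assay for lipophilicity, measured as octanol-water partition; on this read-out higher numbers stand for higher lipophilicity and lower numbers for lower lipophilicity:
- compound 1 `N#Cc1c(-c2ccco2)[n+]([O-])c2ccc(F)cc2[n+]1[O-]` gives 0.983
- compound 2 `COc1ccc2c(c1)[n+]([O-])c(C#N)c(-c1ccco1)[n+]2[O-]` gives 0.354
- compound 3 `Cc1ccc(-c2c(C#N)[n+]([O-])c3cc(F)ccc3[n+]2[O-])cc1` gives 2.48

Compound 3 stands highest of the three. Compound 4 `Cc1ccc(-c2c(C#N)[n+]([O-])c3cc(C)ccc3[n+]2[O-])cc1` has methyl in place of fluoro on an aromatic carbon. The closest measured step is methoxy in place of fluoro, a number 0.63 log units lower from compound 1 to compound 2 (beyond the scatter), but a different group enters there. The step of a number 1.50 log units higher from compound 1 to compound 3 (beyond the scatter) concerns 4-methylphenyl in place of furan-2-yl, which is a different change. Within the data shown here, no measured step has methyl entering, so only a small rise in this assay is tentatively expected. The expected step is a number 0.22 log units higher from compound 3 to compound 4 (within the scatter). For compound 4 the estimate is 2.7, with an expected range from 2.2 to 3.2.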

Compound 4, partition coefficient: 2.33
Estimate against measurement, compound 4: 0.37 log units above; low and high end bracket the measured number.
By their numbers in this assay, from the lowest: compound 2; then compound 1; then compounds 4 and 3 (each within the scatter of the next).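

In this assay, methyl in place of fluoro on this aromatic carbon gives a number 0.15 log units lower from compound 3 to compound 4 (within the scatter), so with 4-methylphenyl on the core, this exchange does not separate the two compounds. The earlier compounds shown here showed only methoxy entering in place of fluoro, with furan-2-yl on the core, as a number 0.63 log units lower from compound 1 to compound 2 (beyond the scatter). Nothing available accounts for the difference between these two steps. Open, from the compounds shown here alone, is whether methyl in place of fluoro gives a similar result with furan-2-yl on the core. Also open, going by these compounds, is how an amine or a carboxylic acid at this position would read out.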